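A few compounds are considered here, and "the series" means these few. Any claim that something is new, unique, unknown or untested is made for them only; others in the source may bear on it.

Measured so far in a functional assay on HT-29 cells (Homo sapiens) for antiproliferative activity, with a stated time of 48 h; a lower number here means that less compound is needed, a higher number that more compound is needed for the effect:
- compound 1 `Nc1ccc(NC(=O)CCCCCCC(=O)NO)cc1` at 18000 nM
- compound 2 `O=C(CCCCCCC(=O)Nc1ccc(Cl)cc1)NO` at 2100 nM

Of these two, compound 2 has the lowest number at 2100 nM and compound 1 lies above it, beyond the scatter. Next in line is compound 3 `N#Cc1ccc(NC(=O)CCCCCCC(=O)NO)cc1` with cyano in place of chloro on an aromatic carbon, para to a large group, counted as cyano in place of chloro on an aromatic carbon in the structures. Within the data shown here, only one measured step bears on this place, and it is modest: an 8.6-fold lower number from compound 1 to compound 2 (0.93 log units; beyond the scatter) with chloro in place of amino. Among the measured compounds shown here, no measured compound carries cyano, so that step gives size only, not direction. A step within the scatter is therefore expected in this assay, leaning slightly upward. The expected change is a 1.2-fold higher number from compound 2 to compound 3 (0.08 log units; within the scatter) as an estimate. For compound 3 the estimated value is 2500 nM with an expected range from 800 nM to 8000 nM in this series.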

Compound 3, half-maximal effective concentration: 42000 nM
Beside the measured number, compound 3's estimate is 17-fold (1.23 log units) below it, outside the stated range (above it).
By their numbers in this assay, from the lowest: compound 2; then compound 1; then compound 3.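

In this assay, the aromatic carbon para to a large group responds more strongly to the choice of substituent than the earlier amino-to-chloro step showed: replacing chloro with cyano gives a 20-fold higher number from compound 2 to compound 3 (1.30 log units; beyond the scatter). Cyano also falls behind amino, with a 2.3-fold higher number from compound 1 to compound 3 (0.37 log units; beyond the scatter), so of the three groups chloro alone gives the lowest number of the series, and the two other groups both lie well above it. No available measurement explains why chloro and cyano differ so much at this carbon.

Going by these compounds, whether a fluoro, bromo or methyl group at this carbon would stay close to compound 2 or move towards compound 3 remains open. Also open, on these data alone, is whether the order of the three groups holds with a longer chain.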